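Aminophenyl enone pyrazoles: methoxy removal on the aryl ring

A few compounds are considered here, and "the series" means these few. Any claim that something is new, unique, unknown or untested is made for them only; others in the source may bear on it.

Measured so far:
compound 1, `COc1ccc(-c2cc(/C=C/C(=O)c3ccc(N)cc3)[nH]n2)cc1`, -100% in a functional assay on U-251 cells (Homo sapiens) for cytotoxicity, read by sulforhodamine B assay, with a stated time of 48 h, tested at 100 uM; a higher number here means a weaker effect of the compound at the concentration tested, a lower number a stronger effect
compound 2, `COc1cc(-c2cc(/C=C/C(=O)c3ccc(N)cc3)[nH]n2)cc(OC)c1OC`, -98% in this assay

Both measured compounds give a reading at the bottom of the scale in this assay. Compound 2 stands at the top of the two numbers shown, but compound 1 lies within the scatter of it, so the two readings are not distinguishable. For the measured compounds named here, no step between measured compounds is available for the methoxy pattern on the aryl ring.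

The next compound is compound 3, `COc1ccc(-c2cc(/C=C/C(=O)c3ccc(N)cc3)[nH]n2)cc1OC`. Relative to compound 2 the change is hydrogen in place of methoxy on an aromatic carbon.

With both measured readings at the floor and within the scatter of each other, no step beyond the scatter is expected in this assay from this change; the expected step is a number 1 percentage points lower from compound 2 to compound 3 (within the scatter). Compound 3 is therefore estimated at -99%, with a range from -100% to -88%.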

Compound 3, a percentage reported as activity, at one concentration (the size of the read-out at that concentration, not a potency): -96%
Estimate against measurement, compound 3: 3 percentage points below; the range from low to high includes it.
By their numbers in this assay, from the lowest: compounds 1, 2 and 3 (each within the scatter of the next).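

Hydrogen in place of methoxy on this aromatic carbon, ortho to a methoxy group and meta to a large group, gives a number 2 percentage points higher from compound 2 to compound 3 (within the scatter) in this assay, and methoxy in place of hydrogen on an aromatic carbon gives a number 4 percentage points higher from compound 1 to compound 3 (within the scatter). Neither change separates the compounds at the concentration tested, so this position tolerates either methoxy or hydrogen in this read-out, although readings this close to the bottom of the scale leave little room for a difference to appear. No independent data bear on this result.

As far as these compounds go, whether the aryl ring needs any methoxy at all remains open. Also open, from the compounds shown here alone, is whether a hydroxyl, an amine or a carboxylic acid on this aromatic carbon would move the reading away from the bottom of the scale.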